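Replacing cyano with methyl in a long-lived compound

This account rests on a few compounds, and the source may have more. Where it says the series, first, only, none or still open, it means among the compounds named here.

In an ADME assay (liver, Mus musculus) for metabolic stability, using microsomes (a lower number here means that the compound disappears faster, a higher number that the compound lasts longer), compound 1 (`CCCc1nc2ccccn2c1C(=O)NCc1ccc(-c2ccccc2)cc1`) gives 0.145 h and compound 2 (`CCc1nc2ccc(Cl)cn2c1C(=O)NCc1ccc(-c2ccccc2Cl)cc1`) gives 0.218 h. Compound 3 (`CCc1nc2ccc(Cl)cn2c1C(=O)NCc1ccc(-c2ccc(C#N)cc2)cc1`) gives > 1 h, which is a limit of the assay and not a number. So the true half-life of compound 3 is not known.

Compound 4 (`CCc1nc2ccc(Cl)cn2c1C(=O)NCc1ccc(-c2ccc(C)cc2)cc1`) differs from compound 3 in one place: methyl in place of cyano on an aromatic carbon. This puts methyl in place of cyano on an aromatic carbon, para to a large group.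

Among the compounds with values here, no measured step shows this exact swap. The nearest is an at least 4.5-fold higher number from compound 2 to compound 3 (0.66 log units; beyond the scatter), where 4-cyanophenyl took the place of 2-chlorophenyl, so a change in this part of the molecule can move the number beyond the scatter. Within the data shown here, compound 3, at the limit, is also the only measured compound with cyano. Part or all of that gain may therefore be lost, and compound 2 at 0.218 h is the closest guide.

A lower number is expected, an estimated at least 3.3-fold lower number from compound 3 to compound 4 (0.52 log units; beyond the scatter). The expected half-life of compound 4 is 0.3 h, with an estimated range of 0.12 h to 0.8 h.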

Compound 4, half-life: 0.677 h
Estimate against measurement, compound 4: 2.3-fold (0.35 log units) below, and the stated range covers the measured number.
By their numbers in this assay, from the lowest: compounds 1 and 2 (each within the scatter of the next); then compound 4. At a limit, above all of these: compound 3.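

In this assay, 4-methylphenyl in place of 2-chlorophenyl gives a 3.1-fold higher number from compound 2 to compound 4 (0.49 log units; beyond the scatter), so a gain over 2-chlorophenyl here does not require cyano. Methyl in place of cyano gives an at least 1.4-fold lower number from compound 3 to compound 4 (0.16 log units; that floor lies within the scatter), so this swap is not shown to cost anything beyond the scatter. Compound 3 stands at a limit of the assay and not at a number, which leaves the true gap between cyano and methyl unknown: the limit of > 1 h in this assay, at which 1 of the 4 values shown sits.

The change from 2-chlorophenyl to 4-methylphenyl alters both the group and its place on the ring, and the compounds shown do not separate these two effects. They also leave open how other groups in the place held by methyl and cyano, such as methoxy or an amine, would behave in this assay.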